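The source may hold more compounds than are shown below. What is called first, only, known or untested is meant among the compounds shown, and "the series" means these compounds.

In a functional assay on DU-145 cells (Homo sapiens) for cytotoxicity, read by sulforhodamine B assay, with a stated time of 48 h (a lower number here means a stronger inhibitor of growth, a higher number a weaker inhibitor of growth), three compounds built on the same core have been tested, and each gives only a limit of the assay rather than a number. Compound 1, `N#Cc1ccc(Nc2nc(Oc3ccnc4ccccc34)nc(N3CCN(c4ccc(F)cc4)CC3)n2)cc1C(F)(F)F`, gives > 100000 nM. Compound 2, `CN1CCN(c2nc(Nc3ccc(C#N)c(C(F)(F)F)c3)nc(Oc3ccnc4ccccc34)n2)CC1`, gives > 100000 nM. Compound 3, `CC(C)N1CCN(c2nc(Nc3ccc(C#N)c(C(F)(F)F)c3)nc(Oc3ccnc4ccccc34)n2)CC1`, gives > 100000 nM. Because all three values sit at the limit of > 100000 nM in this assay, at which 3 of the 3 values shown sit, none of the steps between them can be read in size: they are recorded as a step that the two limits leave unreadable from compound 1 to compound 2, a step that the two limits leave unreadable from compound 1 to compound 3 and a step that the two limits leave unreadable from compound 2 to compound 3. Compound 3 therefore stands only at a limit, as do the two other values shown, and no ordering among the three can be drawn.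

Compound 4, `N#Cc1ccc(Nc2nc(Oc3ccnc4ccccc34)nc(N3CCN(c4ccccc4)CC3)n2)cc1C(F)(F)F`, is not yet measured; it differs from compound 3 by phenyl in place of isopropyl on an amine nitrogen in a ring. For the measured compounds named here, no measured step bears on this change with a readable size, since every step is hidden by the limit; compound 1, which carries 4-fluorophenyl on that same ring nitrogen, also gave only a limit. The expected step is a number no higher from compound 3 to compound 4 (the limit leaves the size open), that is, no readable change. Compound 4 is estimated to give 100000 nM in this assay, with a range from 30000 nM to 300000 nM, and most likely the result is again reported only as a limit.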

Compound 4, concentration for total growth inhibition: > 100000 nM
Compound 4 gave a limit, no number; the forecaster's own chance of this, stated with the estimate: 85%; the middle value sits exactly at the limit.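

Compound 4 joins compound 1, compound 2 and compound 3 in giving only a limit in this assay, so no new step to compound 4 can be read: the limit of > 100000 nM in this assay, at which 4 of the 4 values shown sit.

The compounds shown leave open whether methyl, isopropyl, phenyl and 4-fluorophenyl on the ring nitrogen differ at all in their inhibition of growth.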